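Benzyl in Place of Phenyl, Tried a Second Time

This account rests on a few compounds, and the source may have more. Where it says the series, first, only, none or still open, it means among the compounds named here.

Compound 1 `Nc1ccccc1NC(=O)c1ccc(Cn2cnc3c(Nc4ccccc4)nc(Cl)nc32)cc1` is the reference. In a functional assay on HepG2 cells (Homo sapiens) for antiproliferative activity, read by CCK-8 assay, with a stated time of 72 h, tested at 2 uM (on this read-out lower numbers stand for a weaker effect and higher numbers for a stronger effect at the one concentration tested), compound 1 gives 49.6%. Compound 2 `Nc1ccccc1NC(=O)c1ccc(Cn2cnc3c(NCc4ccccc4)nc(Cl)nc32)cc1` differs from it by benzyl in place of phenyl on a nitrogen on an aromatic ring, a change that produced a number 42.1 percentage points lower from compound 1 to compound 2 (beyond the scatter), so that compound 2 gives 7.55% in this assay. Compound 3 `Nc1ccccc1NC(=O)/C=C/c1ccc(Cn2cnc3c(Nc4ccccc4)nc(Cl)nc32)cc1` differs from compound 1 in its core by 2-((2-aminophenyl)carbamoyl)ethenyl in place of (2-aminophenyl)carbamoyl on an aromatic carbon; this gave a number 33.2 percentage points lower from compound 1 to compound 3 (beyond the scatter), and compound 3 stands at 16.4%. The unmeasured compound 4 `Nc1ccccc1NC(=O)/C=C/c1ccc(Cn2cnc3c(NCc4ccccc4)nc(Cl)nc32)cc1` carries, relative to compound 3, the same change that compound 2 carries relative to compound 1, namely (benzyl in place of phenyl on a nitrogen on an aromatic ring), at a place described in identical words. Because the first instance gave a number 42.1 percentage points lower from compound 1 to compound 2 (beyond the scatter) and compound 3 begins from only 16.4%, a smaller drop is expected, about a number 11.4 percentage points lower from compound 3 to compound 4 (beyond the scatter) in this assay. Compound 4 is therefore expected to give roughly 5%, estimated between -5% and 16%.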

Compound 4, a percentage reported as inhibition, at one concentration (the size of the read-out at that concentration, not a potency): 11.5%
Estimate against measurement, compound 4: 6.5 percentage points below; the measured number falls inside the stated range.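

In this assay, benzyl in place of phenyl gave a number 4.9 percentage points lower from compound 3 to compound 4 (within the scatter), so the change did not carry over from the core of compound 1 with the same size: the same change on two cores in this assay, a number 42.1 percentage points lower (beyond the scatter) from compound 1 to compound 2 and a number 4.9 percentage points lower (within the scatter) from compound 3 to compound 4, 37.2 percentage points apart, beyond the scatter of two such steps. Likewise, 2-((2-aminophenyl)carbamoyl)ethenyl in place of (2-aminophenyl)carbamoyl gave a number 4 percentage points higher from compound 2 to compound 4 (within the scatter), which also differs from its earlier step: the same change on two cores in this assay, a number 33.2 percentage points lower (beyond the scatter) from compound 1 to compound 3 and a number 4 percentage points higher (within the scatter) from compound 2 to compound 4, 37.2 percentage points apart, beyond the scatter of two such steps. This shows that the two changes do not simply add in these four compounds, but it rests on one pair of cores at a single concentration and does not show why the steps differ.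

The compounds shown leave open how a phenethyl group on that nitrogen would read in this assay. They also leave open the effect of a carboxylic acid in place of (2-aminophenyl)carbamoyl.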